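From propylamino to cyclopropylamino on the shared core

The source may hold more compounds than are shown below. What is called first, only, known or untested is meant among the compounds shown, and "the series" means these compounds.

Compound 1 `CCNc1nc(Nc2ccc3c(c2)NC(=O)COC3(C)C)nc2ccoc12`: > 67000 nM
Compound 2 `CCCNc1nc(Nc2ccc3c(c2)NC(=O)COC3(C)C)nc2ccoc12`: > 200000 nM

Both compounds were measured in a physicochemical assay for solubility, read by HPLC, in simulated intestinal fluid, with stated times of 10 min and 2 days, at pH 5; a higher number here means a more soluble compound, a lower number a less soluble compound. In this measurement compound 2 gives > 200000 nM, which is a limit of the assay and not a number. Compound 1 gives > 67000 nM, and this too is a limit. Among the compounds with values here, compound 2 therefore has no exact position, and the one other value offers no exact point of comparison.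

The next compound is compound 3 `CC1(C)OCC(=O)Nc2cc(Nc3nc(NC4CC4)c4occc4n3)ccc21`, which keeps the shared core and changes one group: cyclopropyl in place of propyl on a nitrogen on an aromatic ring. In words, this is cyclopropyl in place of propyl on a nitrogen on an aromatic ring.

Within the data shown here, only one measured step bears on this change, the replacement of hydrogen by methyl on a saturated chain carbon, a step that the two limits leave unreadable from compound 1 to compound 2. It gives no size to carry forward, so no change beyond the scatter is expected in this assay, in either direction. The estimated step is a number no higher from compound 2 to compound 3 (the limit leaves the size open). For compound 3 the estimated value is 200000 nM, with an expected range from 60000 nM to 500000 nM.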

Compound 3, solubility: 158000 nM
For compound 3 the middle estimate is 1.3-fold (0.10 log units) above the measured one; the measured number falls inside the stated range.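

In this assay compound 3 gives 158000 nM, the first exact number among the compounds shown, so cyclopropyl on a nitrogen on an aromatic ring gives this position a measured value and not a limit. Set against propyl at the same place, where the value of compound 2 is itself a limit, the change gives an at least 1.2-fold lower number from compound 2 to compound 3 (0.10 log units; that floor lies within the scatter); the true step may be larger than this floor, but the data show only that it is no smaller. The steps that join compound 1 to the other two compounds cannot be read, and the value of compound 1 is a limit: the limit of > 67000 nM in this assay, at which 1 of the 3 values shown sits.

The compounds shown leave open how large the step from propyl to cyclopropyl really is, and whether the number for compound 3 would hold for other groups that keep the shared core. Also open, going by these compounds, is how a larger ring such as cyclobutyl, a longer chain such as butyl, or a chain ending in a hydroxyl or an amine would read on this nitrogen in this assay.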